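The source may report more compounds than this note shows. Statements on the series, on what has been measured and on what is new or still open speak of the compounds shown alone.

The measured compounds and their numbers in a physicochemical assay for solubility (on this read-out higher numbers stand for higher solubility and lower numbers for lower solubility), are these:
compound 1, `Cc1cc(C)cc(Cc2cc(Br)ccc2OCCn2ccc(=O)[nH]c2=O)c1`, gives 1200 nM;
compound 2, `O=C(c1cc(Cl)cc(Cl)c1)c1cc(Cl)ccc1OCCn1ccc(=O)[nH]c1=O`, gives 1900 nM;
compound 3, `Cc1cc(C)cc(C(=O)c2cc(Cl)ccc2OCCn2ccc(=O)[nH]c2=O)c1`, gives 3700 nM.

Compound 1 stands lowest of the three in this assay. Its nearest neighbour is compound 2, whose number is higher by an amount that lies within the scatter, while compound 3 stands further off, higher by an amount beyond the scatter. The one step shown between compounds differing in a single place is a 1.9-fold higher number from compound 2 to compound 3 (0.29 log units; within the scatter).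

The unmeasured compound 4, `Cc1cc(C)cc(Cc2cc(C)ccc2OCCn2ccc(=O)[nH]c2=O)c1`, is reached from compound 1 by a single change: methyl in place of bromo on an aromatic carbon. For the measured compounds named here, no measured step concerns this exact exchange on this ring. The closest comparison is the step from compound 2 to compound 3, where methyl groups enter in place of halogens on a different ring and the number rises only within the scatter. On that basis only a small move in this assay is expected, if any, and more likely upward than downward. Compound 4 is therefore estimated at 1600 nM, with a range from 800 nM to 3500 nM, which would mean an expected step of a 1.3-fold higher number from compound 1 to compound 4 (0.12 log units; within the scatter).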

Compound 4, solubility: 44400 nM
For compound 4 the middle estimate is 28-fold (1.44 log units) below the measured one; the whole stated range lies below it.
By their numbers in this assay, from the lowest: compounds 1, 2 and 3 (each within the scatter of the next, the first and the last beyond it); then compound 4.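

In this assay the exchange of bromo for methyl, on the aromatic carbon that lies para to a large group and meta to a 3,5-dimethylbenzyl group, gives a 37-fold higher number from compound 1 to compound 4 (1.57 log units; beyond the scatter) and so shows that this single place can move the read-out far beyond the scatter. The exchange is also small by count: 1 heavy atom leaves, 1 heavy atom enters, and no ring, hydrogen-bond donor, hydrogen-bond acceptor or net charge comes or goes, so a change of this modest kind is enough here. For the compounds shown here, the only earlier step between compounds differing in one place, a 1.9-fold higher number from compound 2 to compound 3 (0.29 log units; within the scatter), put methyl groups in place of chloro groups on a different ring and stayed within the scatter, so it gave no sign of what this position could do, and nothing available explains the size of the new step.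

The compounds shown leave open whether the rise comes from bromo leaving or from methyl entering, which a plain hydrogen, a methoxy group or an amine on this same carbon could begin to separate. They also leave open whether the same exchange would carry over to compounds with a carbonyl in place of the methylene of the 3,5-dimethylbenzyl group.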